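From Propyl to Allyl: What Dose to Expect

The source may report more compounds than this note shows. Statements on the series, on what has been measured and on what is new or still open speak of the compounds shown alone.

Compound 1 `C=CCc1c(OC)nc2nc(-c3noc(C)n3)cn2c1C` and compound 2 `CCCc1c(OC)nc2nc(-c3nc(C)cs3)cn2c1C` share a core but differ in two places, so their values can only be set side by side. In a functional assay on the whole organism with Rattus norvegicus as the target (a lower number here means that less compound is needed, a higher number that more compound is needed for the effect), compound 1 gives 10 mg/kg. Compound 2 reaches only a limit of the assay, > 50 mg/kg, not a measured number (the limit of > 50 mg/kg in this assay, at which 1 of the 2 values shown sits). Compound 3 `C=CCc1c(OC)nc2nc(-c3nc(C)cs3)cn2c1C` keeps the core of compound 2 and changes one group: vinyl in place of ethyl on a saturated chain carbon bound to an aromatic carbon. Cut one bond further out, the same difference reads propyl to allyl, the chain that compound 1 carries. Within the data shown here, no measured step carries this change on its own, so the expectation rests on compound 1 at 10 mg/kg. It also leans on compound 2, whose value is only a limit. In this assay the expected step is an at least 1.6-fold lower number from compound 2 to compound 3 (0.22 log units; that floor lies within the scatter), a drop in the dose needed, with its size uncertain: compound 2 shows only a limit. Compound 3 is estimated at 30 mg/kg, with a likely range from 10 mg/kg to 100 mg/kg.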

Compound 3, minimum effective dose: > 50 mg/kg
Compound 3: only a limit was reported (the forecaster's own chance of this, stated with the estimate: 40%); middle value at least 1.6-fold (0.22 log units) away from the limit.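

In this assay compound 3 gives > 50 mg/kg as a limit of the assay, not a number. Among these compounds, compound 1 and compound 3 carry the same allyl chain, so allyl alone does not secure a measurable dose here, and the single change of 4-methyl-1,3-thiazol-2-yl in place of 5-methyl-1,2,4-oxadiazol-3-yl gives an at least 5.0-fold higher number from compound 1 to compound 3 (0.69 log units; beyond the scatter) in the dose needed, a difference beyond the usual scatter. The step from propyl to allyl itself cannot be read, because compound 2 and compound 3 both stop at the same limit: the limit of > 50 mg/kg in this assay, at which 2 of the 3 values shown sit.

Still open, on these data alone, is how a propyl chain behaves when paired with 5-methyl-1,2,4-oxadiazol-3-yl, and whether a longer chain such as butyl would change the dose needed. Also open, as far as these compounds go, is whether an amine in place of the methyl on the thiazole would bring the value down from the limit.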